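The source may report more compounds than this note shows. Statements on the series, on what has been measured and on what is new or still open speak of the compounds shown alone.

Working notes on the series in a physicochemical assay for solubility; on this read-out lower numbers stand for lower solubility and higher numbers for higher solubility. Compound 1 `O=C(CN1CCNCC1)N1CCC(NS(=O)(=O)c2cc(S(=O)(=O)c3ccccc3)ccc2C(F)(F)F)CC1` gives 50000 nM in this assay. Compound 2 `CC(C)(C)OC(=O)N1C(=O)CC[C@H]1C(=O)N1CCC(NS(=O)(=O)c2cc(S(=O)(=O)c3ccccc3)ccc2C(F)(F)F)CC1` gives 50000 nM. Compound 3 `CC(C)(C)CC(=O)N1CCC[C@H]1C(=O)N1CCC(NS(=O)(=O)c2cc(S(=O)(=O)c3ccccc3)ccc2C(F)(F)F)CC1` gives 25000 nM, within the scatter of both other numbers, so no ordering among the three is supported. Among the measured compounds shown here, the one single-point step available, a 2.0-fold lower number from compound 1 to compound 3 (0.30 log units; within the scatter), is within the scatter. Compound 4 `O=C([C@@H]1CCCN1Cc1ccccc1)N1CCC(NS(=O)(=O)c2cc(S(=O)(=O)c3ccccc3)ccc2C(F)(F)F)CC1` differs from compound 3 by benzyl in place of neopentylcarbonyl on an amine nitrogen in a ring. For the measured compounds named here, no measured step bears directly on this change; the only step measured at the same carbonyl carbon, a 2.0-fold lower number from compound 1 to compound 3 (0.30 log units; within the scatter), stayed within the scatter, so in this assay a step of a 1.2-fold higher number from compound 3 to compound 4 (0.08 log units; within the scatter) is expected, that is, none beyond the scatter. Compound 4 is therefore estimated at 30000 nM, with a range of 10000 nM to 90000 nM.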

Compound 4, solubility: 25000 nM
Compound 4: the middle estimate sits 1.2-fold (0.08 log units) above what was measured, within the range that was stated.
By their numbers in this assay, from the lowest: compounds 3, 4, 1 and 2 (each within the scatter of the next).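

In this assay, benzyl in place of neopentylcarbonyl on an amine nitrogen in a ring gives no change at the digits printed from compound 3 to compound 4 (within the scatter), so at this position a group with a carbonyl and one with a six-membered aromatic ring of carbon only are not told apart. 1-Benzylpyrrolidin-2-yl in place of (piperazin-1-yl)methyl on a carbonyl carbon gives a 2.0-fold lower number from compound 1 to compound 4 (0.30 log units; within the scatter), which also separates nothing in this assay.

From the compounds shown here alone, whether a carboxylic acid on that amine nitrogen would give a step beyond the scatter remains open. No measurement on hand accounts for either step.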